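The compounds below may be only part of what the source reports. "The series", "measured", "known", "first", "only" and "open" are said of these compounds alone.

Compound 1 `CCCCS(=O)(=O)NC(=O)[C@@H](NC(=O)c1cccc(Cn2ccnc2)c1)[C@@H](C)CC` has no number in an assay on HEK293 cells for displacement of a labelled ligand from Type-2 angiotensin II receptor (Homo sapiens), tested at 10 uM; on this read-out higher numbers stand for a stronger effect at the one concentration tested and lower numbers for a weaker effect: compound 1 is recorded there as "not determined" (no result reported), so it stands nowhere on the numbers shown. A related compound, compound 2 `CC[C@H](C)[C@H](NC(=O)c1cccc(Cn2ccnc2)c1)C(=O)NNS(=O)(=O)c1ccc(OC)cc1`, gives 20% in this assay, a weak effect at the one concentration tested. Compound 3 `CC[C@H](C)[C@H](NC(=O)c1cccc(Cn2ccnc2)c1)C(=O)NC#N` differs from compound 1 in one place: cyano in place of butylsulfonyl on an amide-type nitrogen. Within the data shown here, with no measured pair to set the size of this step, the expected change in this assay is small, not beyond the usual scatter, in either direction. Compound 3 is estimated to give 15%, within 0% to 40%.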

Compound 3, a percentage reported as inhibition, at one concentration (the size of the read-out at that concentration, not a potency): 9%
The estimate for compound 3 lay 6 percentage points above the measured number; the range from low to high includes it.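

In this assay no step can be read between compound 1 and compound 3. Whether cyano in place of butylsulfonyl changes the read-out stays open, and nothing shown bears on a cause.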